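A few compounds are considered here, and "the series" means these few. Any claim that something is new, unique, unknown or untested is made for them only; others in the source may bear on it.

Values in an ADME assay on microsomes (Rattus norvegicus) for metabolic stability (on this read-out lower numbers stand for a shorter-lived compound and higher numbers for a longer-lived compound), as measured so far

- compound 1 (`O=C(C1CCC1)N1N=CCC1c1ccccc1`): 0.583 h
- compound 2 (`O=C(C1CCCCC1)N1N=CCC1c1ccccc1`): 0.0833 h

Compound 2 holds the lower of the two numbers, and compound 3 (`O=C(C1CCOCC1)N1N=CCC1c1ccccc1`) is the next to be read against it. The change is oxan-4-yl in place of cyclohexyl on a carbonyl carbon. Going by the values given here, only one measured step bears on this carbon, a 7.0-fold lower number from compound 1 to compound 2 (0.85 log units; beyond the scatter) and beyond the scatter. Among the compounds with values here, it alters ring size, and no measured pair tests a ring hetero atom. In this assay the expected change is a 4.0-fold higher number from compound 2 to compound 3 (0.60 log units; beyond the scatter) and thus a rise smaller than the measured one. For compound 3 the estimated value is 0.33 h with an expected range from 0.12 h to 0.9 h on this measure.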

Compound 3, half-life: > 1.5 h
Compound 3 ended at the assay's limit (the forecaster's own chance of this, stated with the estimate: 3%); middle value at least 4.5-fold (0.65 log units) away from the limit.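

In this assay, the group on the carbonyl carbon matters through more than ring size: at the same six-membered ring size, oxan-4-yl in place of cyclohexyl gives an at least 18-fold higher number from compound 2 to compound 3 (1.25 log units; beyond the scatter). A six-membered ring does not by itself bring the low number, as oxan-4-yl in place of cyclobutyl gives an at least 2.5-fold higher number from compound 1 to compound 3 (0.41 log units; beyond the scatter). Compound 3 stands at a limit of the assay, not at a number: the limit of > 1.5 h in this assay, at which 1 of the 3 values shown sits.

Still open, as far as these compounds go, is how far compound 3 lies past that limit. Also open, from the compounds shown here alone, is whether a ring amine such as piperidin-4-yl, or a smaller oxygen ring such as oxetan-3-yl, follows oxan-4-yl.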